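Replacing the cyclohexyloxy group with an arylamino group

A few compounds are considered here, and "the series" means these few. Any claim that something is new, unique, unknown or untested is made for them only; others in the source may bear on it.

Within the data shown here, in a functional assay on NCI-H1299 cells (Homo sapiens) for antiproliferative activity, read by MTT assay, with a stated time of 72 h (on this read-out higher numbers stand for weaker inhibition and lower numbers for stronger inhibition), compound 2 `O=C(C1=C(OC2CCCCC2)C(=O)N(CCCn2ccnc2)C1c1ccc(Br)cc1)c1ccccc1` gives 19900 nM, the lowest of the two numbers so far; compound 1 `CCOC1=C(C(=O)c2ccccc2)C(c2ccc(Br)cc2)N(CCCn2ccnc2)C1=O` gives 28900 nM, and the step of a 1.5-fold lower number from compound 1 to compound 2 (0.16 log units; within the scatter) lies within the scatter. Compound 3 `O=C(C1=C(Nc2ccc(OC(F)(F)F)cc2)C(=O)N(CCCn2ccnc2)C1c1ccc(Br)cc1)c1ccccc1` differs from compound 2 in that ((4-(trifluoromethoxy)phenyl)amino in place of cyclohexyloxy on a double-bonded ring carbon). Among the measured compounds shown here, the only measured step changes the same position, but it swapped one alkoxy group for another and barely moved the number, so it says little about an amine bearing an aromatic ring. Compound 3 is therefore expected near compound 2, at 15000 nM (range 4000 nM to 60000 nM), meaning a step of a 1.3-fold lower number from compound 2 to compound 3 (0.12 log units; within the scatter) is estimated.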

Compound 3, half-maximal inhibitory concentration: 11500 nM
Compound 3: the middle estimate sits 1.3-fold (0.12 log units) above what was measured, and the stated range covers the measured number.
By their numbers in this assay, from the lowest: compounds 3, 2 and 1 (each within the scatter of the next, the first and the last beyond it).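

In this assay, among these compounds, putting (4-(trifluoromethoxy)phenyl)amino in place of ethoxy gives a 2.5-fold lower number from compound 1 to compound 3 (0.40 log units; beyond the scatter), the first step at this position to pass the scatter, though the gain is modest. In place of cyclohexyloxy it gives a 1.7-fold lower number from compound 2 to compound 3 (0.24 log units; within the scatter), so this position accepts an amine bearing an aromatic ring with no loss of activity. Nothing available explains this shift. Going by these compounds, what remains open is whether the nitrogen or the aromatic ring matters more. A cyclohexylamino group and a plain phenylamino group at this position would help separate the nitrogen, the ring and the trifluoromethoxy group.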